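Shortening the ester side chain of a phenolic cinnamate

A few compounds are considered here, and "the series" means these few. Any claim that something is new, unique, unknown or untested is made for them only; others in the source may bear on it.

Of the compounds shown here, three sharing one core have been tested. Compound 1 `COc1cc(/C=C/C(=O)OCCc2cccc(F)c2)cc(OC)c1O` gives 230 nM in an assay on PMNL cells for inhibition of Polyunsaturated fatty acid 5-lipoxygenase (Homo sapiens), read by HPLC, with stated times of 5 min and 15 min; a lower number here means a stronger inhibitor, a higher number a weaker inhibitor. Compound 2 `COc1cc(/C=C/C(=O)OCCc2ccccc2F)cc(OC)c1O` gives 240 nM, and compound 3 `COc1ccccc1CCOC(=O)/C=C/c1cc(OC)c(O)c(OC)c1` gives 250 nM. Compound 1 has the lowest of the three numbers, but the steps of a 1.0-fold higher number from compound 1 to compound 2 (0.02 log units; within the scatter) and a 1.1-fold higher number from compound 1 to compound 3 (0.04 log units; within the scatter) are both within the scatter, as is a 1.0-fold higher number from compound 2 to compound 3 (0.02 log units; within the scatter), so the three compounds cannot be told apart.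

Compound 4 `CCCOC(=O)/C=C/c1cc(OC)c(O)c(OC)c1` has not yet been measured. It differs from compound 1 by methyl in place of 3-fluorophenyl on a saturated chain carbon, two bonds along the chain from an oxygen next to a carbonyl group. The measured steps all exchange one group on the six-membered aromatic ring of carbon only for another, whereas here that whole ring leaves and only a methyl enters; those steps therefore bear on the change only loosely, and they show that swapping groups on the ring barely moves the number. Losing the ring altogether is a larger change, and a weaker inhibitor is expected, with a step of a 2.2-fold higher number from compound 1 to compound 4 (0.34 log units; beyond the scatter) in this assay. Compound 4 is estimated at 500 nM, within 150 nM to 1600 nM.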

Compound 4, half-maximal inhibitory concentration: 710 nM
Compound 4: middle estimate off by 1.4-fold (0.15 log units), on the low side, within the range that was stated.
By their numbers in this assay, from the lowest: compounds 1, 2 and 3 (each within the scatter of the next); then compound 4.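

Until now, every change left the aromatic ring in place and none moved the number beyond the scatter. For the compounds shown here, replacing the whole ring with methyl at this position in this assay is the first change that does, giving a 3.1-fold higher number from compound 1 to compound 4 (0.49 log units; beyond the scatter) and a 3.0-fold higher number from compound 2 to compound 4 (0.47 log units; beyond the scatter) and also a 2.8-fold higher number from compound 3 to compound 4 (0.45 log units; beyond the scatter) in the same direction. Among these four compounds, then, the 3-fluorophenyl, 2-fluorophenyl and 2-methoxyphenyl groups all give stronger inhibitors than methyl, and nothing measured here says what lies behind this.

On these data alone, what remains open is whether the aromatic ring itself matters or whether a larger group of any kind would serve as well. A longer straight chain such as hexyl would help separate those two readings, and a plain phenyl would show how the ring behaves with no added group.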